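The compounds below may be only part of what the source reports. "The series", "measured", "known", "first", "only" and "open" are said of these compounds alone.

Of the compounds shown here, three sharing one core have been tested in a functional assay on PC-3 cells (Homo sapiens) for inhibition, read by sulforhodamine B assay, with a stated time of 48 h; on this read-out higher numbers stand for weaker inhibition of growth and lower numbers for stronger inhibition of growth. Compound 2 `COc1cc(-c2nn(-c3cccc(NC(=O)c4ccc(Cl)c(C(F)(F)F)c4)c3)cc2-c2ccncc2)ccc1Cl` gives 1290 nM, the highest number of the three. Compound 1 `O=C(Nc1cccc(-n2cc(-c3ccncc3)c(-c3ccc(Cl)c(O)c3)n2)c1)Nc1ccc(Cl)c(Cl)c1` gives 834 nM, a number within the usual scatter of compound 2. Compound 3 `O=C(Nc1cccc(-n2cc(-c3ccncc3)c(-c3ccc(Cl)c(O)c3)n2)c1)Nc1cc(C(F)(F)F)cc(C(F)(F)F)c1` gives 319 nM, a lower number, beyond the scatter. Compound 4 `COc1cc(-c2nn(-c3cccc(NC(=O)Nc4cccc(C(F)(F)F)c4)c3)cc2-c2ccncc2)ccc1Cl` differs from compound 2 in one place: (3-(trifluoromethyl)phenyl)amino in place of 4-chloro-3-(trifluoromethyl)phenyl on a carbonyl carbon. Compounds 1 and 3 likewise carry an amino group on the carbonyl carbon, and their numbers sit within the scatter of compound 2 or below it, so a small move towards lower numbers is expected, possibly staying within the scatter. In this assay the expected step is a 2.0-fold lower number from compound 2 to compound 4 (0.30 log units; within the scatter). Compound 4 is estimated at 650 nM, with a range from 250 nM to 1700 nM.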

Compound 4, concentration for 50% growth inhibition: 372 nM
Beside the measured number, compound 4's estimate is 1.7-fold (0.24 log units) above it; the measured number falls inside the stated range.
By their numbers in this assay, from the lowest: compounds 3 and 4 (each within the scatter of the next); then compounds 1 and 2 (each within the scatter of the next).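

In this assay, for the compounds shown here, the change on this carbonyl carbon gives a 3.5-fold lower number from compound 2 to compound 4 (0.54 log units; beyond the scatter) and is the first step here between compounds that differ in one place, lying beyond the usual scatter. The entering group adds an amino nitrogen with its hydrogen-bond donor and has no chlorine, so two differences travel together in this one step. No measurement given here accounts for the step. Which difference matters remains open. A (4-chloro-3-(trifluoromethyl)phenyl)amino group on the same carbonyl carbon would keep the nitrogen and the chlorine together and help separate the two.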